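Dimethylamino in Place of Chloro on Compound 1

The compounds below may be only part of what the source reports. "The series", "measured", "known", "first", "only" and "open" are said of these compounds alone.

Measured compounds:
compound 1, `N[C@H]1CC[C@H](Nc2c(C(=O)NCc3ccc(Cl)cc3)nc(Br)c3cccnc23)CC1` — 1000 nM
compound 2, `N[C@H]1CC[C@H](Nc2c(C(=O)NCc3ccccn3)nc(Br)c3cccnc23)CC1` — > 20000 nM
compound 3, `N[C@H]1CC[C@H](Nc2c(C(=O)NCc3ccc(F)cc3)nc(Br)c3cccnc23)CC1` — "not determined" (no result reported)

For the measured compounds named here, in a functional assay on HEY cells (Homo sapiens) for cytotoxicity, read by MTT assay, with a stated time of 72 h (a higher number here means a weaker inhibitor, a lower number a stronger inhibitor), compound 1 gives 1000 nM, the only number reported among the three measured compounds. For compound 2 only a limit is reported, > 20000 nM (the limit of > 20000 nM in this assay, at which 1 of the 3 values shown sits). Compound 3 has no result recorded. Going by the values given here, the one measured step, an at least 20-fold higher number from compound 1 to compound 2 (1.30 log units; beyond the scatter), replaces the whole aromatic ring, and it is the only evidence at hand.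

Compound 4, `CN(C)c1ccc(CNC(=O)c2nc(Br)c3cccnc3c2N[C@H]2CC[C@H](N)CC2)cc1`, keeps the ring of compound 1 and changes only its substituent: dimethylamino in place of chloro on an aromatic carbon. Among the compounds with values here, this is a smaller change than the one from compound 1 to compound 2, which showed that the group on the amide-type nitrogen can matter a great deal. A modest weakening is therefore expected, close to the scatter, as a 2.5-fold higher number from compound 1 to compound 4 (0.40 log units; beyond the scatter). Compound 4 is expected to give about 2500 nM in this assay, with a range from 800 nM to 8000 nM.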

Compound 4, half-maximal inhibitory concentration: 5300 nM
For compound 4 the middle estimate is 2.1-fold (0.33 log units) below the measured one, and the stated range covers the measured number.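

In this assay, dimethylamino in place of chloro, with the ring itself kept, gives a 5.3-fold higher number from compound 1 to compound 4 (0.72 log units; beyond the scatter), so this position responds to its substituent alone, which the earlier replacement of the whole ring could not show. With 4-(dimethylamino)phenyl in place of pyridin-2-yl, the step is an at least 3.7-fold lower number from compound 2 to compound 4 (0.57 log units; beyond the scatter), so compound 4 keeps a measurable value on the same benzyl amide arrangement as compound 1. Compound 2 is known only through a limit, so that step has no upper size: the limit of > 20000 nM in this assay, at which 1 of the 4 values shown sits.

For the compounds shown here, only two substituents on this ring have numbers, which is too few to show a trend across groups. Going by these compounds, whether a methoxy group, a primary amine or a carboxylic acid at the same aromatic carbon would fall nearer compound 1 or compound 4 remains open.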